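Swapping Nitro for Cyano on a Shared Core

The compounds below may be only part of what the source reports. "The series", "measured", "known", "first", "only" and "open" are said of these compounds alone.

Of the compounds shown here, three built on one shared core have been tested in a functional assay on OVCAR-4 cells (Homo sapiens) for inhibition, read by sulforhodamine B assay, with a stated time of 48 h, tested at 10 uM; a higher number here means more inhibition of growth at the concentration tested, a lower number less inhibition of growth. Compound 1 `CCOC(=O)c1ccc(Nc2ccnc(SCC(=O)c3ccc([N+](=O)[O-])cc3)n2)cc1` gives 20%. Compound 2 `COc1ccc(C(=O)CSc2nccc(Nc3cccc(C(C)=O)c3)n2)cc1` gives 19%, and compound 3 `CC(=O)c1ccc(Nc2ccnc(SCC(=O)c3ccc(Cl)cc3)n2)cc1` gives 18%. Compound 1 holds the highest of the three numbers, yet all three lie within the usual scatter of one another, so the three cannot be told apart. Compound 4 `CCOC(=O)c1ccc(Nc2ccnc(SCC(=O)c3ccc(C#N)cc3)n2)cc1` differs from compound 1 in one place: cyano in place of nitro on an aromatic carbon. Within the data shown here, no step between measured compounds shows what such a change does here. With the known numbers so close together, the expected step is a number 2 percentage points lower from compound 1 to compound 4 (within the scatter), none beyond the scatter. Compound 4 is therefore estimated at 18%, within a range from 7% to 30%.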

Compound 4, percent growth inhibition at one concentration: 35%
For compound 4 the middle estimate is 17 percentage points below the measured one; the whole stated range lies below it.
By their numbers in this assay, from the lowest: compounds 3, 2 and 1 (each within the scatter of the next); then compound 4.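

The earlier compounds shown here offered no step to read, and this pair gives the first: the aromatic carbon para to a large group is sensitive to what it carries. In this assay, cyano in place of nitro gives a number 15 percentage points higher from compound 1 to compound 4 (beyond the scatter), a modest but real change. Nothing measured here explains this rise.

An amine or a carboxylic acid on this same carbon remains an open case. So does whether 4-cyanophenyl would give a similar step on other versions of the shared core.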